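This account rests on a few compounds, and the source may have more. Where it says the series, first, only, none or still open, it means among the compounds named here.

Compound 3 `CC(=O)NC1CCN(c2ccc3cc(NC(=O)CCc4ccc(C(F)(F)F)cc4)ccc3n2)C1` gives 440 nM in a functional assay on HEK293 cells for activation of melanin-concentrating hormone receptor 1 (Rattus norvegicus), read by inositol phosphate accumulation; on this read-out higher numbers stand for an effect only at larger amounts of compound and lower numbers for an effect already at smaller amounts. Among the three measured compounds it stands second highest: compound 2 `Nc1ccc2cc(NC(=O)CCc3ccc(C(F)(F)F)cc3)ccc2n1` gives 720 nM, a gap of a 1.6-fold lower number from compound 2 to compound 3 (0.21 log units; within the scatter), and compound 1 `CC(C)N(C)c1ccc2cc(NC(=O)CCc3ccc(C(F)(F)F)cc3)ccc2n1` gives 140 nM, a gap of a 3.1-fold higher number from compound 1 to compound 3 (0.50 log units; beyond the scatter). Compound 4 `O=C(CCc1ccc(C(F)(F)F)cc1)Nc1ccc2nc(N3CC4CC3CO4)ccc2c1` is not yet measured; it differs from compound 3 by a group of 7 heavy atoms (5 carbon, 1 nitrogen, 1 oxygen; 2 five-membered non-aromatic rings with 1 hetero atom each) in place of a group of 9 heavy atoms (6 carbon, 2 nitrogen, 1 oxygen; one five-membered non-aromatic ring with 1 hetero atom), on an aromatic carbon. All three measured steps change the group on this same aromatic carbon, and they were modest: a 5.1-fold higher number from compound 1 to compound 2 (0.71 log units; beyond the scatter), a 3.1-fold higher number from compound 1 to compound 3 (0.50 log units; beyond the scatter), a 1.6-fold lower number from compound 2 to compound 3 (0.21 log units; within the scatter). Therefore a step of at most modest size is expected here, in either direction. Compound 4 is expected to give about 300 nM, with a range of 100 nM to 900 nM. That estimate means an expected step of a 1.5-fold lower number from compound 3 to compound 4 (0.17 log units; within the scatter).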

Compound 4, half-maximal effective concentration: 70 nM
Beside the measured number, compound 4's estimate is 4.3-fold (0.63 log units) above it, outside the stated range (below it).
By their numbers in this assay, from the lowest: compounds 4 and 1 (each within the scatter of the next); then compounds 3 and 2 (each within the scatter of the next).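

The group with 2 five-membered non-aromatic rings gives larger steps than any seen earlier at this aromatic carbon: a 10-fold lower number from compound 2 to compound 4 (1.01 log units; beyond the scatter) and a 6.3-fold lower number from compound 3 to compound 4 (0.80 log units; beyond the scatter). Yet a 2.0-fold lower number from compound 1 to compound 4 (0.30 log units; within the scatter), so a ring-free group and this two-ring group cannot be told apart here. Nothing available explains these steps.

From the compounds shown here alone, it remains open whether a morpholine or a piperidine on this carbon would give numbers like those of compound 1 and compound 4. Going by these compounds, it also remains open whether an acetamido group on another ring carbon would change the number.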